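Swapping an aryl ring for a methylpiperazine on the shared core

A few compounds are considered here, and "the series" means these few. Any claim that something is new, unique, unknown or untested is made for them only; others in the source may bear on it.

Compound 1 `CC(C)(C)n1cc2c(n1)C(=O)CC1(CCN(C(=O)c3cc(-c4ccc(F)cc4)nc4ccccc34)CC1)O2`: in a functional assay on MDA-MB-231 cells (Homo sapiens) for inhibition, read by MTT assay, with a stated time of 72 h (a lower number here means a stronger inhibitor, a higher number a weaker inhibitor), compound 1 gives > 10000 nM, which is a limit of the assay and not a number.
Compound 2 `CC(C)(C)n1cc2c(n1)C(=O)CC1(CCN(C(=O)c3cc(-c4ccc(Br)cc4)nc4ccccc34)CC1)O2`: compound 2 gives > 10000 nM, again only a limit.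
Compound 3 `CC(C)(C)n1cc2c(n1)C(=O)CC1(CCN(C(=O)c3cc(-c4ccncc4)nc4ccccc34)CC1)O2`: compound 3 gives 1650 nM.

Compound 1 thus sits at the limit of > 10000 nM in this assay, at which 2 of the 3 values shown sit, where two of the three values shown rest, so only its ceiling is known. Going by the values given here, the one readable step is an at least 6.0-fold lower number from compound 1 to compound 3 (0.78 log units; beyond the scatter), which shows that pyridin-4-yl in place of 4-fluorophenyl brings a real gain. The step that the two limits leave unreadable from compound 1 to compound 2 tells nothing, since both ends are limits.

Compound 4 `CN1CCN(c2cc(C(=O)N3CCC4(CC3)CC(=O)c3nn(C(C)(C)C)cc3O4)c3ccccc3n2)CC1` differs from compound 1 in one place: 4-methylpiperazin-1-yl in place of 4-fluorophenyl on an aromatic carbon. Among the compounds with values here, this exchange has no measured counterpart here, for it trades an aromatic ring for a non-aromatic ring with two hetero atoms rather than one aromatic ring for another. Within the data shown here, the only guide is compound 3, whose step an at least 6.0-fold lower number from compound 1 to compound 3 (0.78 log units; beyond the scatter) shows that leaving 4-fluorophenyl can help. A comparable, modest gain is expected, an at least 3.3-fold lower number from compound 1 to compound 4 (0.52 log units; beyond the scatter), though with wide uncertainty. Compound 4 is therefore estimated at 3000 nM, with a range from 600 nM to 15000 nM.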

Compound 4, half-maximal inhibitory concentration: 8130 nM
Compound 4: the middle estimate sits 2.7-fold (0.43 log units) below what was measured; measured number inside the range.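

At this carbon next to the ring nitrogen, moving away from 4-fluorophenyl does not by itself secure the level of compound 3: in this assay there is a 4.9-fold higher number from compound 3 to compound 4 (0.69 log units; beyond the scatter), so 4-methylpiperazin-1-yl falls clearly short of pyridin-4-yl. Going by these compounds alone, this is the first comparison at this position with real numbers at both ends, and it shows that the choice of ring placed here matters even between two groups that each carry nitrogen. Against the two halogen-bearing aryl compounds only floors can be read, an at least 1.2-fold lower number from compound 1 to compound 4 (0.08 log units; that floor lies within the scatter) and an at least 1.2-fold lower number from compound 2 to compound 4 (0.08 log units; that floor lies within the scatter), so whether compound 4 truly improves on them stays unsettled because both rest at a limit: the limit of > 10000 nM in this assay, at which 2 of the 4 values shown sit.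

The compounds shown leave open whether the advantage of pyridin-4-yl belongs to its aromatic ring or to where its nitrogen lies, a question that pyridin-3-yl at this carbon would address. They also leave open how other non-aromatic rings, such as morpholin-4-yl or piperidin-1-yl, would compare with 4-methylpiperazin-1-yl.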